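A methoxy group added to compound 2

The source may hold more compounds than are shown below. What is called first, only, known or untested is meant among the compounds shown, and "the series" means these compounds.

In a functional assay on FM3A cells (Mus musculus) for antiproliferative activity, with a stated time of 48 h (on this read-out higher numbers stand for weaker inhibition and lower numbers for stronger inhibition), compound 2 `C=C(Br)C(=O)Nc1ccc(C(=O)/C=C/c2ccccc2)cc1` gives 690 nM and compound 1 `C=C(Br)C(=O)Nc1ccc(/C=C/C(=O)c2ccc(OC)cc2)cc1` gives 1200 nM and these two numbers lie within the usual scatter of each other. Compound 3 `C=C(Br)C(=O)Nc1ccc(C(=O)/C=C/c2cccc(OC)c2)cc1` brings one change to compound 2, methoxy in place of hydrogen on an aromatic carbon (methoxy in place of hydrogen on an aromatic carbon, meta to a large group). Within the data shown here, no measured pair shows this change, so no shift beyond the scatter is expected in this assay in either direction. The expected step of a 1.2-fold lower number from compound 2 to compound 3 (0.06 log units; within the scatter) is small. Compound 3 is estimated at 600 nM with an expected range of 200 nM to 1800 nM.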

Compound 3, half-maximal inhibitory concentration: 1800 nM
The estimate for compound 3 lay 3.0-fold (0.48 log units) below the measured number, within the range that was stated.
By their numbers in this assay, from the lowest: compounds 2, 1 and 3 (each within the scatter of the next, the first and the last beyond it).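

Adding a methoxy group to the phenyl of compound 2, meta to a large group, gives the first measured step at this position: in this assay the change brings a 2.6-fold higher number from compound 2 to compound 3 (0.42 log units; beyond the scatter) and so a modest loss of inhibition. This position is therefore not indifferent to the change, at least for phenyl to 3-methoxyphenyl on this core. Nothing measured here explains the loss.

As far as these compounds go, whether a hydroxyl, a fluorine or an amine at this place would also weaken inhibition remains open. So does the effect of a methoxy group elsewhere on this ring.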